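The source may report more compounds than this note shows. Statements on the series, on what has been measured and on what is new or still open speak of the compounds shown alone.

Compound 2 `COc1cc(-c2nn(-c3cccc(NC(=O)Nc4cccc(C(F)(F)F)c4)c3)cc2-c2ccncc2)ccc1Cl` gives 306 nM in a functional assay on SF-295 cells (Homo sapiens) for inhibition, read by sulforhodamine B assay, with a stated time of 48 h (on this read-out higher numbers stand for weaker inhibition of growth and lower numbers for stronger inhibition of growth), the lowest of the two numbers in hand. Compound 1 `COc1cc(-c2nn(-c3cccc(NC(=O)c4ccc(Cl)c(C(F)(F)F)c4)c3)cc2-c2ccncc2)ccc1Cl` gives 1380 nM; the step of a 4.5-fold lower number from compound 1 to compound 2 (0.65 log units; beyond the scatter) alters both the linker and the group on the carbonyl carbon at once. The part that belongs to chloro cannot be separated from the amide-to-urea exchange. Among the measured compounds shown here, compound 3 `COc1cc(-c2nn(-c3cccc(NC(=O)Nc4ccc(Cl)c(C(F)(F)F)c4)c3)cc2-c2ccncc2)ccc1Cl` is not yet measured. chloro in place of hydrogen on an aromatic carbon The only measured step that touches this change is the combined one from compound 1 to compound 2, and it does not isolate the chloro for hydrogen exchange, so it gives no direction on its own. For compound 3 a step of a 1.1-fold higher number from compound 2 to compound 3 (0.06 log units; within the scatter) is therefore expected, one that should not exceed the usual scatter. Compound 3 is expected to give about 350 nM in this assay, with a range from 120 nM to 1000 nM.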

Compound 3, concentration for 50% growth inhibition: 840 nM
The estimate for compound 3 lay 2.4-fold (0.38 log units) below the measured number, and the stated range covers the measured number.
By their numbers in this assay, from the lowest: compound 2; then compounds 3 and 1 (each within the scatter of the next).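

In this assay, chloro in place of hydrogen, ortho to the trifluoromethyl group and para to a large group, now stands alone in the urea series, with a 2.7-fold higher number from compound 2 to compound 3 (0.44 log units; beyond the scatter), so this position does not take the added chloro without a loss of growth inhibition. With the 4-chloro-3-(trifluoromethyl)phenyl part held fixed, the amide-to-urea exchange gives a 1.6-fold lower number from compound 1 to compound 3 (0.22 log units; within the scatter), so of the two single changes inside the earlier combined step, only the chloro exchange lies beyond the scatter. Nothing at hand explains the loss seen with chloro.

The compounds shown leave open whether the chloro step would be similar on the amide linker, as they include no amide lacking the chloro. They also leave open how an amine or a fluoro at this same position would compare with hydrogen and chloro.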